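The compounds below may be only part of what the source reports. "The series", "measured", "known", "first", "only" and "open" are said of these compounds alone.

Compound 1 `CCc1nc2ccc(Cl)cn2c1C(=O)NCc1ccc2oc(C3CCCCC3)nc2c1` stands lowest of the two numbers seen in an ADME assay on microsomes from liver (Rattus norvegicus) for metabolic stability (a lower number here means that the compound disappears faster, a higher number that the compound lasts longer), where compound 1 gives 0.0867 h. Its nearest neighbour is compound 3 `CCc1nc2cc(Cl)ccn2c1C(=O)NCc1ccc2oc(C)nc2c1`, which in this assay gives 0.172 h, a gap that lies within the scatter. Compound 2 `CCc1nc2cc(Cl)ccn2c1C(=O)NCc1ccc2oc(-c3ccc(F)cc3)nc2c1` gives > 2 h in this assay, which is a limit of the assay rather than a number. Compound 4 `CCc1nc2ccc(Cl)cn2c1C(=O)NCc1ccc2oc(-c3ccc(OC(F)(F)F)cc3)nc2c1` differs from compound 1 by 4-(trifluoromethoxy)phenyl in place of cyclohexyl on an aromatic carbon. Within the data shown here, the one measured step that bears on this change is an at least 11-fold lower number from compound 2 to compound 3 (1.06 log units; beyond the scatter), a large step in which the compound carrying the aromatic ring at this place sits far above the compound carrying the small alkyl group. The change from compound 1 to compound 4 runs the opposite way, with an aromatic ring entering in place of a saturated one. For compound 4 a large rise is therefore expected, a 14-fold higher number from compound 1 to compound 4 (1.14 log units; beyond the scatter). The limit recorded as the limit of > 2 h in this assay, at which 1 of the 3 values shown sits, may cut off the number for compound 4. Compound 4 is expected to give 1.2 h in this assay, between 0.35 h and 4 h.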

Compound 4, half-life: > 2 h
Compound 4 gave a limit, no number; the forecaster's own chance of this, stated with the estimate: 40%; middle value at least 1.6-fold (0.22 log units) from the limit.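

In this assay, putting 4-(trifluoromethoxy)phenyl in place of cyclohexyl on this aromatic carbon gives an at least 23-fold higher number from compound 1 to compound 4 (1.36 log units; beyond the scatter). The earlier step set only a methyl against 4-fluorophenyl on the core of compound 2, whereas this step sets one six-membered ring against another on the core of compound 1, so a ring of that size is not enough on its own: the saturated ring stays low and the aromatic one reaches the top of the range. The reading for compound 4 is a limit and not a number, so the true size of the step stays unknown: the limit of > 2 h in this assay, at which 2 of the 4 values shown sit.

The compounds shown leave open how much of the rise belongs to the aromatic ring and how much to the trifluoromethoxy group, which a plain phenyl would separate. They also leave open how a piperidine ring or a longer alkyl chain would fare at this place.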